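Aryl Amine Variation in an Acrylamide Series: Toward Compound 4

A few compounds are considered here, and "the series" means these few. Any claim that something is new, unique, unknown or untested is made for them only; others in the source may bear on it.

compound 1 `C=CC(=O)Nc1cccc(NC(=O)CSc2nc(Nc3ccccc3)c3ccccc3n2)c1`: 8120 nM
compound 2 `C=CC(=O)Nc1cccc(NC(=O)CSc2nc(Nc3ccccc3Br)c3ccccc3n2)c1`: 19300 nM
compound 3 `C=CC(=O)Nc1cccc(NC(=O)CSc2nc(Nc3cccc(OC)c3)c3ccccc3n2)c1`: 7940 nM

In a functional assay on NCI-H1975 cells (Homo sapiens) for inhibition, read by MTT assay, with a stated time of 72 h (on this read-out higher numbers stand for weaker inhibition and lower numbers for stronger inhibition), compound 3 gives the lowest of the three numbers, but its nearest neighbour is compound 1 and the gap a 1.0-fold lower number from compound 1 to compound 3 (0.01 log units; within the scatter) lies within the scatter, so the two cannot be ordered. The only movement beyond the scatter is a 2.4-fold higher number from compound 1 to compound 2 (0.38 log units; beyond the scatter); the comparison a 2.4-fold lower number from compound 2 to compound 3 (0.39 log units; beyond the scatter) is its mirror.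

Compound 4 `C=CC(=O)Nc1cccc(NC(=O)CSc2nc(Nc3ccc(CC)cc3)c3ccccc3n2)c1` has not been measured in this assay. It differs from compound 3 by 4-ethylphenyl in place of 3-methoxyphenyl on a nitrogen on an aromatic ring. For the measured compounds named here, no measured step tests an alkyl group on this ring. Going by the values given here, the steps that bear on it are those varying the same ring: a 1.0-fold lower number from compound 1 to compound 3 (0.01 log units; within the scatter) shows a methoxy leaving the number where it was, and a 2.4-fold higher number from compound 1 to compound 2 (0.38 log units; beyond the scatter) shows a bromo giving a modest weakening. The range of outcomes seen so far is therefore narrow, from no change to a modest rise. Among the compounds with values here, a number close to compound 3 is expected, leaning slightly toward a higher value since a 2.4-fold higher number from compound 1 to compound 2 (0.38 log units; beyond the scatter) was the only change beyond the scatter and it went upward. The expected step is a 1.2-fold higher number from compound 3 to compound 4 (0.08 log units; within the scatter). Compound 4 is accordingly estimated at 9500 nM, with a range from 4000 nM to 23000 nM in this assay.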

Compound 4, half-maximal inhibitory concentration: 8270 nM
Compound 4: middle estimate off by 1.1-fold (0.06 log units), on the high side, and the stated range covers the measured number.
By their numbers in this assay, from the lowest: compounds 3, 1 and 4 (each within the scatter of the next); then compound 2.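

The 4-ethylphenyl group is the only ring bearing an alkyl group among these compounds, and in this assay this substitution on the nitrogen-linked ring leaves the number in place, with a 1.0-fold higher number from compound 1 to compound 4 (0.01 log units; within the scatter) for ethyl in place of hydrogen and a 1.0-fold higher number from compound 3 to compound 4 (0.02 log units; within the scatter) for the exchange with 3-methoxyphenyl. Compounds 1, 3 and 4 therefore cannot be ordered, although 3-methoxyphenyl counts one hydrogen-bond acceptor and 4-ethylphenyl none, so that difference in count does not separate the two in this read-out. Compound 2 stays apart from the other three, now also through a 2.3-fold lower number from compound 2 to compound 4 (0.37 log units; beyond the scatter), and nothing measured at hand accounts for either the lack of change or this separation.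

Open, on these data alone, is whether the higher number of compound 2 goes with the bromo itself or with its place on the ring, as bromo occurs only as 2-bromophenyl here. Also open, as far as these compounds go, is whether the same lack of change would hold for an amine, a carboxylic acid or a longer alkyl chain on this ring.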